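Chloro in place of methyl: a one-atom exchange in two pyridyl ureas

The compounds below may be only part of what the source reports. "The series", "measured", "known", "first", "only" and "open" are said of these compounds alone.

The account follows two compounds that share a cyclic amidine–urea core and differ in the pyridine ring that hangs from the urea. Compound 1, `CN1CC(=O)N/C1=N\C(=O)Nc1ncccc1Cl`, carries a chloro group on its ring. In an in vitro ADME assay on microsomes from liver (Homo sapiens) for metabolic stability (a higher number here means faster removal of the compound, a lower number slower removal), compound 1 gives 42 mL.min-1.g-1. Compound 2, `Cc1cnccc1NC(=O)/N=C1\NC(=O)CN1C`, carries a methyl group instead and has its ring nitrogen placed differently. In this assay, for the measured compounds named here, compound 2 gives 2 mL.min-1.g-1, the lowest of the two numbers measured so far; compound 1 sits at a markedly higher number, a gap that lies beyond the usual scatter of repeated runs.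

Compound 3, `CN1CC(=O)N/C1=N\C(=O)Nc1ccncc1Cl`, is the next compound to be measured. Compared with compound 2 its change is chloro in place of methyl on an aromatic carbon; the exchange sits on an aromatic carbon of a six-membered aromatic ring with one nitrogen, ortho to a large group and two atoms from the ring nitrogen. Going by the values given here, no step between two measured compounds isolates this exchange, so the data give no direct guide. The writer expects a modest upward step a 2.5-fold higher number from compound 2 to compound 3 (0.40 log units; beyond the scatter) in this assay, at the edge of the scatter rather than clearly beyond it. Compound 3 is therefore estimated at 5 mL.min-1.g-1, with a range from 1.5 mL.min-1.g-1 to 20 mL.min-1.g-1.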

Compound 3, intrinsic clearance in microsomes: 15 mL.min-1.g-1
Beside the measured number, compound 3's estimate is 3.0-fold (0.48 log units) below it; low and high end bracket the measured number.
By their numbers in this assay, from the lowest: compound 2; then compound 3; then compound 1.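

In this assay, for the compounds shown here, this is the first change that can be read on its own, and the exchange of methyl for chloro is not silent here: the shared core stays fixed and the ring nitrogen stays in place, yet the result is a 7.5-fold higher number from compound 2 to compound 3 (0.88 log units; beyond the scatter). The place in question is an aromatic carbon of a six-membered aromatic ring with one nitrogen, ortho to a large group and two atoms from the ring nitrogen, so this position responds to the swap of one heavy atom for another, with no change in the count of hydrogen-bond donors or acceptors. The data show the size and direction of this step, but nothing measured here accounts for it.

Going by these compounds alone, it remains open whether chloro in place of methyl would give a step of similar size with the ring nitrogen placed as in compound 1, as no step links compound 1 to either of the other compounds. Also open is how an amine, a methoxy group or a longer alkyl chain on the same aromatic carbon would read in this assay, since the compounds shown carry only methyl and chloro there.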